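Compound 1 to compound 4: benzoyl gives way to methyl

The source may hold more compounds than are shown below. What is called first, only, known or untested is meant among the compounds shown, and "the series" means these compounds.

In a physicochemical assay for lipophilicity, read by HPLC, measured as chromatographic lipophilicity, at pH 7.4 (a lower number here means a more polar compound, a higher number a more lipophilic compound), compound 1 (`O=C(c1ccccc1)N1CCC(C(=O)N2N=CCC2c2ccccc2)CC1`) stands highest of the three measured compounds at 4.4 on this scale. Compound 3 (`Cc1nnc(N2CCC(C(=O)N3N=CC[C@H]3c3cc(F)cc(F)c3)CC2)o1`) comes nearest at 3.6 and compound 2 (`CC(C)(C)C(=O)N1N=CCC1c1cc[nH]n1`) lies furthest at 2.7 with both gaps beyond the scatter.

Compound 4 (`CN1CCC(C(=O)N2N=CCC2c2ccccc2)CC1`) has no reading yet. It differs from compound 1 by methyl in place of benzoyl on an amine nitrogen in a ring.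

Among the compounds with values here, no two measured compounds differ in one place, so no measured step sizes this change directly. The expectation rests on the change itself and on the spread of the series, where compound 2 at 2.7 shows how far under compound 1 a number can lie. A large downward step in this assay is expected, well beyond the scatter. The estimated step (a number 2.00 log units lower from compound 1 to compound 4 (beyond the scatter)) is downward. For compound 4 the estimated value is 2.4 (expected range 1.7 to 3.1).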

Compound 4, distribution coefficient: 1.1
Compound 4: the middle estimate sits 1.30 log units above what was measured, and the stated range ends above it.
By their numbers in this assay, from the lowest: compound 4; then compound 2; then compound 3; then compound 1.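

In this assay, the group on an amine nitrogen in a ring proves to be a site of large change: methyl in place of benzoyl gives a number 3.30 log units lower from compound 1 to compound 4 (beyond the scatter). Within the data shown here, this is the first step that differs in one place, so the position is now read directly rather than inferred from compounds that differ in several places. No measurement shown accounts for the size of this step.

With one pair at this position, the step cannot be divided between the carbonyl and the aromatic ring that leave together. An acetyl group or a benzyl group on the same nitrogen, each keeping only one of these two features, would separate their shares.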